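The source may hold more compounds than are shown below. What is called first, only, known or untested is meant among the compounds shown, and "the series" means these compounds.

Going by the values given here, compound 2 `CC1CC(C)CN(c2nc(Nc3ccc(C#N)c(C(F)(F)F)c3)nc(Oc3ccnc4ccccc34)n2)C1` is the one compound of three that gives an actual number in a functional assay on DU-145 cells (Homo sapiens) for cytotoxicity, read by sulforhodamine B assay, with a stated time of 48 h; on this read-out lower numbers stand for stronger inhibition of growth and higher numbers for weaker inhibition of growth: 27200 nM. Compound 1 `N#Cc1ccc(Nc2nc(Oc3ccnc4ccccc34)nc(N3CCN(C(c4ccccc4)c4ccc(Cl)cc4)CC3)n2)cc1C(F)(F)F` gives > 100000 nM, which is a limit of the assay rather than a number. Compound 3 `N#Cc1ccc(Nc2nc(Oc3ccnc4ccccc34)nc(N3CCN(C(c4ccccc4)c4ccccc4)CC3)n2)cc1C(F)(F)F` gives > 100000 nM, again a limit. Among the compounds with values here, the only measured single change, hydrogen in place of chloro on an aromatic carbon, is a step that the two limits leave unreadable from compound 1 to compound 3, so it says nothing about size.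

Compound 4 `CC(C)N1CCN(c2nc(Nc3ccc(C#N)c(C(F)(F)F)c3)nc(Oc3ccnc4ccccc34)n2)CC1` differs from compound 2 by 4-isopropylpiperazin-1-yl in place of 3,5-dimethylpiperidin-1-yl on an aromatic carbon. Within the data shown here, no measured step covers this change; the one measured step, a step that the two limits leave unreadable from compound 1 to compound 3, sits elsewhere and is unreadable. Among the measured compounds shown here, what can be said is that compound 1 and compound 3, which carry a piperazine as compound 4 does, both sit at the limit of > 100000 nM in this assay, at which 2 of the 3 values shown sit, while the piperidine compound 2 gives the only number. Compound 4 is therefore expected to be weaker than compound 2, estimated at 50000 nM, with a range from 12000 nM to 150000 nM. The expected step from compound 2 to compound 4 is a 1.8-fold higher number from compound 2 to compound 4 (0.26 log units; within the scatter), held loosely, since the isopropyl group of compound 4 is much smaller than the diarylmethyl groups of compound 1 and compound 3.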

Compound 4, concentration for 50% growth inhibition: > 100000 nM
Compound 4 was reported as a limit; the forecaster's own chance of this, stated with the estimate: 40%; middle value at least 2.0-fold (0.30 log units) away from the limit.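

In this assay, the position opposite the ring nitrogen now has its first readable step: 4-isopropylpiperazin-1-yl in place of 3,5-dimethylpiperidin-1-yl gives an at least 3.6-fold higher number from compound 2 to compound 4 (0.56 log units; beyond the scatter). Compound 4 is reported only as a limit, so this step gives a minimum size and not an exact one. Compound 4 carries an isopropyl group where compound 1 and compound 3 carry diarylmethyl groups, yet all three reach the same limit, so a diarylmethyl group is not needed for a piperazine compound to sit there, and the only number shown still belongs to the piperidine compound 2: the limit of > 100000 nM in this assay, at which 3 of the 4 values shown sit.

The compounds shown leave open whether the loss follows the second ring nitrogen or the isopropyl group. An unsubstituted piperidine, a morpholine or an N-methylpiperazine at this position would help separate these two parts of the change.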